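The source may report more compounds than this note shows. Statements on the series, on what has been measured and on what is new or still open speak of the compounds shown alone.

Measured compounds:
compound 1 `CC(C)=CCC/C(C)=C/CC/C(C)=C/C(=O)NC(=N)N` with 22000 nM
compound 2 `CC(C)=CCC/C(C)=C/CC/C(C)=C/C(=O)NC(=N)NC(=O)C=C(C)C` with 23400 nM
compound 3 `CC(C)=CCC/C(C)=C/C(=O)NC(=N)NC(=O)C=C(C)C` with 41500 nM

All three were examined in a functional assay on MCF7 cells (Homo sapiens) for inhibition, read by MTT assay, with a stated time of 72 h; on this read-out lower numbers stand for stronger inhibition of growth and higher numbers for weaker inhibition of growth. Compound 2 serves as the point from which the others are reached. Removing one end group, described as hydrogen in place of (2-methylprop-1-en-1-yl)carbonyl on an amine nitrogen, gives compound 1, and the step of a 1.1-fold lower number from compound 2 to compound 1 (0.03 log units; within the scatter) shows that this change left the read-out essentially unmoved. Shortening the chain instead, described as hydrogen in place of 3-methylbut-2-en-1-yl on a saturated chain carbon bound to a double-bonded chain carbon, gives compound 3, and the step of a 1.8-fold higher number from compound 2 to compound 3 (0.25 log units; within the scatter) is likewise within the scatter, so compound 3 cannot be set apart from compound 2 or compound 1 on these numbers.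

Compound 4 `CC(C)=CCC/C(C)=C/C(=O)NC(=N)N` has not yet been measured. It differs from compound 3 by hydrogen in place of (2-methylprop-1-en-1-yl)carbonyl on an amine nitrogen, the same change that takes compound 2 to compound 1; the place is described in the same words in both cases, and the two cores differ only by hydrogen in place of 3-methylbut-2-en-1-yl on a saturated chain carbon bound to a double-bonded chain carbon. Since the earlier step of a 1.1-fold lower number from compound 2 to compound 1 (0.03 log units; within the scatter) was small, compound 4 is expected to show a similarly small step, a 1.1-fold lower number from compound 3 to compound 4 (0.04 log units; within the scatter), in this assay. For the measured compounds named here, on that basis compound 4 is estimated to give 38000 nM in this assay, with a likely range from 20000 nM to 75000 nM, an expectation resting on the single earlier instance of this change and on the measured value of compound 3, 41500 nM.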

Compound 4, concentration for 50% growth inhibition: 52200 nM
Compound 4: middle estimate off by 1.4-fold (0.14 log units), on the low side, and the stated range covers the measured number.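

In this assay, putting hydrogen in place of (2-methylprop-1-en-1-yl)carbonyl on the amine nitrogen gives a 1.3-fold higher number from compound 3 to compound 4 (0.10 log units; within the scatter), and the change reads the same on the two cores: the same change on two cores in this assay, a 1.1-fold lower number (0.03 log units; within the scatter) from compound 2 to compound 1 and a 1.3-fold higher number (0.10 log units; within the scatter) from compound 3 to compound 4, 1.3-fold (0.13 log units) apart, within the scatter of two such steps. Putting hydrogen in place of 3-methylbut-2-en-1-yl on the saturated chain carbon gives a 2.4-fold higher number from compound 1 to compound 4 (0.38 log units; beyond the scatter), which lies beyond the scatter, yet it cannot be told apart from its earlier counterpart, which lay within the scatter: the same change on two cores in this assay, a 1.8-fold higher number (0.25 log units; within the scatter) from compound 2 to compound 3 and a 2.4-fold higher number (0.38 log units; beyond the scatter) from compound 1 to compound 4, 1.3-fold (0.13 log units) apart, within the scatter of two such steps. For the compounds shown here, these results show that both changes carried over between cores in this assay with no detectable difference, but each comparison rests on only one pair of steps, and the small size of the carbonyl steps shows only that removing this end group had no visible effect on either core, not that any larger effect would transfer.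

The compounds shown leave open whether a longer chain than that of compound 1, or a fully saturated chain, would move the read-out further. They also leave open how other end groups on the amine nitrogen, such as an acetyl or a benzoyl group, or a carboxylic acid in place of the whole nitrogen-rich end, would read in this assay.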